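The source may hold more compounds than are shown below. What is called first, only, known or untested is meant among the compounds shown, and "the series" means these compounds.

In a functional assay on RKOp27 cells (Homo sapiens) for cytotoxicity, read by MTT assay, with a stated time of 3 days (on this read-out higher numbers stand for weaker inhibition and lower numbers for stronger inhibition), compound 1 `N#Cc1c(O)nc(SCc2nc3ccccc3[nH]2)nc1-c1ccccc1` gives 6.09 nM, and on this read-out it is the highest of the three numbers recorded so far, which means it is the weakest of the three, though only one of the gaps to the others is large enough to count. Compound 2 `N#Cc1c(NN)nc(SCc2nc3ccccc3[nH]2)nc1-c1ccccc1` gives 2.55 nM, and compound 3 `N#Cc1c(Nc2ccccn2)nc(SCc2nc3ccccc3[nH]2)nc1-c1ccccc1` gives 3.8 nM. The step of a 2.4-fold lower number from compound 1 to compound 2 (0.38 log units; beyond the scatter) is the one clear movement here; the step of a 1.6-fold lower number from compound 1 to compound 3 (0.20 log units; within the scatter) and the step of a 1.5-fold higher number from compound 2 to compound 3 (0.17 log units; within the scatter) both fall inside the range that repeated measurements of one compound can show, so compounds 2 and 3 cannot be told apart on these numbers.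

Compound 4 `N#Cc1c(Nc2nccs2)nc(SCc2nc3ccccc3[nH]2)nc1-c1ccccc1` has not yet been measured. It is built from compound 1 by the change ((1,3-thiazol-2-yl)amino in place of hydroxy on an aromatic carbon). For the measured compounds named here, the closest precedent is the step from compound 1 to compound 3, where another ring-bearing amino group replaced the same hydroxy group and the number moved down only within the scatter; the step to compound 2, where a smaller amino group took the same place, moved it down a little further. Taken together these suggest that compound 4 will land somewhat below compound 1, with a step of a 1.5-fold lower number from compound 1 to compound 4 (0.18 log units; within the scatter) expected, and the estimated value of compound 4 is 4 nM, within a range from 2 nM to 9 nM.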

Compound 4, half-maximal inhibitory concentration: 3.2 nM
Compound 4: the middle estimate sits 1.3-fold (0.10 log units) above what was measured; the measured number falls inside the stated range.
By their numbers in this assay, from the lowest: compounds 2, 4, 3 and 1 (each within the scatter of the next, the first and the last beyond it).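

Placing a larger ring-bearing group on this aromatic carbon, next to the ring nitrogen and ortho to a cyano group, gives in this assay a step of a 1.9-fold lower number from compound 1 to compound 4 (0.28 log units; within the scatter), so a five-membered aromatic ring containing sulfur can stand here without the number rising, and the position is not limited to six-membered rings such as the pyridin-2-yl of compound 3. Changing what sits on the nitrogen makes no readable difference, with a 1.2-fold lower number from compound 3 to compound 4 (0.07 log units; within the scatter) for the swap of one ring for the other and a 1.3-fold higher number from compound 2 to compound 4 (0.10 log units; within the scatter) for the swap of the small amino group for the thiazole, so compounds 2, 3 and 4 cannot be told apart on these numbers, even though only compound 2 stands clearly apart from compound 1. Nothing available here explains why these different groups give such similar numbers.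

A plain phenyl on the same nitrogen would show whether the hetero atoms of the ring matter at all. A saturated group in the same place, such as morpholine or a short ethyl chain, remains an open case, since every group shown on that nitrogen is either aromatic or a bare amino group.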